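Carboxy on the aryl hydrazone nitrogen-linked ring

This account rests on a few compounds, and the source may have more. Where it says the series, first, only, none or still open, it means among the compounds named here.

Compound 1 `CC1CCC(=NNc2ccccc2)c2ncc(C(=O)O)c(=O)n21` is the anchor of this small set. In a functional assay on the whole organism with Rattus norvegicus as the target (on this read-out lower numbers stand for an effect already at smaller amounts and higher numbers for an effect only at larger amounts of compound), compound 1 gives 1.2 umol/kg. Compound 2 `CC1CCC(=NNc2ccccc2C(=O)O)c2ncc(C(=O)O)c(=O)n21` carries the change (carboxy in place of hydrogen on an aromatic carbon). For compound 2 the read-out is only a limit, > 100 umol/kg. Going by the values given here, the measured step of an at least 83-fold higher number from compound 1 to compound 2 (1.92 log units; beyond the scatter) is the only complete pair here. The limit sits where the limit of > 100 umol/kg in this assay, at which 2 of the 3 values shown sit, places it, so the true size of that step is open at the top.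

Compound 3 `CC1CCC(C)(N=Nc2ccccc2)c2ncc(C(=O)O)c(=O)n21` has a different core; how the two cores differ is not broken down here. For compound 3 this assay returns only a limit, > 100 umol/kg.

Compound 4 `CC1CCC(C)(N=Nc2ccccc2C(=O)O)c2ncc(C(=O)O)c(=O)n21` is not yet measured. It stands to compound 3 as compound 2 stands to compound 1, through carboxy in place of hydrogen on an aromatic carbon: the same change, at a place described in the same words, ortho to a large group on a six-membered aromatic ring of carbon only. Among the compounds with values here, in the one measured instance this change moved the number far in the direction of an effect only at larger amounts. Compound 3 already sits at the limit of this assay, so the step that the limit leaves unreadable from compound 3 to compound 4 is expected to be uncertain in size and is most likely to end again at the limit. Compound 4 is therefore estimated at 400 umol/kg, with a range from 100 umol/kg to 3000 umol/kg, and a reported number rather than a limit is not expected.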

Compound 4, dose for 50% inhibition: > 100 umol/kg
Compound 4: a limit, no number; the forecaster's own chance of this, stated with the estimate: 90%; the middle value is on the limit's open side.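

In this assay compound 4 returns > 100 umol/kg as a limit, not a number. Going by these compounds alone, with compound 3 also at a limit, no step between compound 3 and compound 4 can be read: the limit of > 100 umol/kg in this assay, at which 3 of the 4 values shown sit.

The compounds shown leave open how far carboxy in place of hydrogen moves the read-out on the core of compound 3, and how large that change truly is on the core of compound 1.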